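Taking the bromo off compound 2

The source may hold more compounds than are shown below. What is called first, only, known or untested is meant among the compounds shown, and "the series" means these compounds.

Compound 1 (`CC1(C)C2CCC1(C)C(OC(=O)/C=C/c1ccc(O)c(O)c1[N+](=O)[O-])C2`) gives 52900 nM
Compound 2 (`CC1(C)C2CCC1(C)C(OC(=O)/C=C/c1cc(O)c(O)c(Br)c1)C2`) gives 15200 nM

In a functional assay on HL-60 cells (Homo sapiens) for inhibition, read by MTT assay (a lower number here means a stronger inhibitor, a higher number a weaker inhibitor), compound 2 has the lower of the two numbers (15200 nM), and its gap to compound 1 lies beyond the scatter. Compound 3 (`CC1(C)C2CCC1(C)C(OC(=O)/C=C/c1ccc(O)c(O)c1)C2`) has not yet been measured. It differs from compound 2 by having hydrogen in place of bromo on an aromatic carbon. Going by the values given here, no measured pair shows this change, so the expectation is loose: a small rise in this assay that may stay within the scatter. The expected step is a 1.4-fold higher number from compound 2 to compound 3 (0.14 log units; within the scatter) on this reasoning. Compound 3 is estimated at 21000 nM with a range from 8000 nM to 55000 nM as the likely span.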

Compound 3, half-maximal inhibitory concentration: 3350 nM
Beside the measured number, compound 3's estimate is 6.3-fold (0.80 log units) above it; the measured number lies below the stated range.
By their numbers in this assay, from the lowest: compound 3; then compound 2; then compound 1.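

Swapping bromo for hydrogen on the aromatic carbon ortho to a hydroxy group gives a 4.5-fold lower number from compound 2 to compound 3 (0.66 log units; beyond the scatter) in this assay and so bromo at this place is not a neutral passenger. Swapping nitro for hydrogen gives a 16-fold lower number from compound 1 to compound 3 (1.20 log units; beyond the scatter) and so compound 3, with neither group, has the lowest number of the three. Nothing available here explains either step.

From the compounds shown here alone, whether any group on this carbon raises the number, or only bromo, remains open. A methyl group or an amine at the same place could separate those two readings.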